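A few compounds are considered here, and "the series" means these few. Any claim that something is new, unique, unknown or untested is made for them only; others in the source may bear on it.

Of the compounds shown here, three have so far been measured in a functional assay on synaptosomes from brain (strain Sprague-Dawley) for agonist activity at Nicotinic acetylcholine receptor alpha6/alpha3/beta2/beta3 (Rattus norvegicus); on this read-out higher numbers stand for larger maximal responses and lower numbers for smaller maximal responses. Compound 1 `C1=C(c2cccnc2)C[C@H]2CNC[C@@H]1C2` gives 73% in this assay, while compound 2 `C1=C(c2cccnc2)C[C@@H]2CNC[C@H]1C2` gives 49%. Between them lies a number 24 percentage points lower from compound 1 to compound 2 (beyond the scatter), and the only structural basis of that step is the fact that compounds 1 and 2 differ only in the configuration as drawn. Compound 3 `C1=C(c2cncc(Oc3ccccc3)c2)CC2CNCC1C2` gives 57% in this assay; among the three numbers it stands second highest, within the scatter of compound 2 and beyond the scatter below compound 1.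

Compound 4 `CC(C)Oc1cncc(C2=CC3CNCC(C2)C3)c1` has not yet been measured. It differs from compound 3 in a single place: isopropyl in place of phenyl on an oxygen on an aromatic ring. Among the measured compounds shown here, the one measured step, from compound 1 to compound 2, concerns configuration alone and involves no exchange of one group for another on an oxygen, so no measured step bears on this change. With nothing to point either way, the expectation for the step in this assay is none beyond the usual scatter, and the step expected from compound 3 to compound 4 is a number 2 percentage points lower from compound 3 to compound 4 (within the scatter). Compound 4 is therefore estimated to reach 55% in this assay, with a range expected from 35% to 75%.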

Compound 4, largest response reached (reported as percent of maximum), in percent of the reference or control that the assay uses: 86%
The estimate for compound 4 lay 31 percentage points below the measured number; measured number above the stated range.
By their numbers in this assay, from the lowest: compounds 2 and 3 (each within the scatter of the next); then compound 1; then compound 4.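

Among the compounds shown here, the exchange of phenoxy for isopropoxy gives the first measured change of a group in this assay, and it produces a number 29 percentage points higher from compound 3 to compound 4 (beyond the scatter), so the group on this oxygen clearly affects the maximal response, which the earlier pair, differing only in configuration, could not show. A phenyl ring on this oxygen is therefore not needed for a large maximal response, and isopropyl, with 3 heavy atoms against 6 and no ring, gives the larger response of this pair. No measured evidence here bears on why this exchange raises the number.

As far as these compounds go, it remains open whether the rise belongs to isopropyl alone or would extend to other groups on this oxygen, such as methyl, a longer chain like n-butyl, or a chain carrying an amine. From the compounds shown here alone, compounds 3 and 4 are drawn without configuration, while configuration alone gives a number 24 percentage points lower from compound 1 to compound 2 (beyond the scatter), so what each mirror-image form of compound 3 and compound 4 would give also stays open.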